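The compounds below may be only part of what the source reports. "The series", "measured", "known", "first", "only" and "open" are said of these compounds alone.

Measured compounds:
compound 1 `C/C(=N\O)c1ccc(NC(=O)CSc2nnc(-c3ccccc3)n2-c2ccccc2)cc1`, 66%
compound 2 `CCn1c(SCC(=O)Nc2ccc(/C(C)=N/O)cc2)nnc1-c1ccc(OC)c(OC)c1`, 73%

Both were tested in a functional assay on the whole organism (strain albino) for inhibition, with Rattus norvegicus as the target, read by paw edema, with stated times of 30 min and 5 h, at a dose of 0.28 mmol/kg by the oral route; a lower number here means less inhibition, a higher number more inhibition at the dose given (going by the name of the read-out). Compound 1 gives 66% there, and compound 2 gives 73%. Compound 2 holds the higher of the two numbers, but the gap to compound 1 lies within the usual scatter of this kind of measurement, so the two cannot be ranked against each other on these data.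

The next compound in this account, compound 3 `CCn1c(SCC(=O)Nc2ccc(/C(C)=N/O)cc2)nnc1-c1ccccc1`, has not yet been measured. It differs from compound 2 in one place: phenyl in place of 3,4-dimethoxyphenyl on an aromatic carbon. For the measured compounds named here, compound 1 also carries phenyl rather than 3,4-dimethoxyphenyl, though it differs from compound 3 elsewhere as well, so no clean step is available to lean on.

Going by the values given here, with only two measured values, both close together, compound 3 is expected to land in the same region. The step of a number 5 percentage points lower from compound 2 to compound 3 (within the scatter) is expected to be small and within the scatter, in either direction. Compound 3 is therefore estimated at 68% in this assay, with a range from 54% to 80%.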

Compound 3, a percentage reported as inhibition, in the whole organism at one dose (the size of the read-out at that dose, not a potency): 66%
Compound 3: middle estimate off by 2 percentage points, on the high side; the range from low to high includes it.
By their numbers in this assay, from the lowest: compounds 1, 3 and 2 (each within the scatter of the next).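

On the aromatic carbon of the five-membered aromatic ring with 3 nitrogen, phenyl in place of 3,4-dimethoxyphenyl gives a number 7 percentage points lower from compound 2 to compound 3 (within the scatter) in this assay, so this clean exchange gives no sign that the read-out at this dose depends on which of the two groups sits there. For the compounds shown here, the new compound also gives the first clean reading on the aromatic nitrogen, which the earlier pair could not give as they differ in two places: ethyl in place of phenyl gives no change at the digits printed from compound 1 to compound 3 (within the scatter). Nothing measured alongside these numbers offers an explanation for either step.

The compounds shown leave open whether a group of another kind on that aromatic carbon, such as a pyridine ring or a carboxylic acid, or a longer chain such as butyl on the aromatic nitrogen, would take the read-out beyond the scatter. Each value also comes from a single oral dose, so these numbers say nothing about potency.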